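The source may report more compounds than this note shows. Statements on the series, on what has been measured and on what is new or still open speak of the compounds shown alone.

Measured so far:
- Compound 1 `Cc1ccc(S(=O)(=O)NCCCNc2nccc(-c3c(-c4cccc(F)c4)nc4sccn34)n2)cc1`: 8380 nM
- Compound 2 `O=C(NCCNc1nccc(-c2c(-c3cccc(F)c3)nc3sccn23)n1)c1ccc(Cl)cc1`: 2570 nM
- Compound 3 `O=C(NCCNc1nccc(-c2c(-c3cccc(F)c3)nc3sccn23)n1)c1ccccc1`: 5060 nM

In a functional assay on A-375 cells (Homo sapiens) for cytotoxicity, read by MTT assay (a higher number here means a weaker inhibitor, a lower number a stronger inhibitor), compound 1 has the highest of the three numbers, with compound 3 nearest and compound 2 furthest. Compound 4 `O=S(=O)(NCCCNc1nccc(-c2c(-c3cccc(F)c3)nc3sccn23)n1)c1ccc(Cl)cc1` differs from compound 1 by chloro in place of methyl on an aromatic carbon on the 4-methylphenyl ring of the sulfonyl group. Going by the values given here, the only measured step touching chloro is a 2.0-fold higher number from compound 2 to compound 3 (0.29 log units; within the scatter), which stayed within the scatter, while the larger step of a 3.3-fold lower number from compound 1 to compound 2 (0.51 log units; beyond the scatter) changed the linker as well and so bears only loosely here. The expectation for compound 4 is therefore a small step, if any, toward a lower number: a 1.4-fold lower number from compound 1 to compound 4 (0.15 log units; within the scatter). Compound 4 is estimated at 6000 nM, with a range from 2500 nM to 14000 nM.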

Compound 4, half-maximal inhibitory concentration: 5900 nM
For compound 4 the middle estimate is 1.0-fold (0.01 log units) above the measured one; the range from low to high includes it.
By their numbers in this assay, from the lowest: compounds 2, 3, 4 and 1 (each within the scatter of the next, the first and the last beyond it).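

In this assay, replacing 4-methylphenyl with 4-chlorophenyl gives a 1.4-fold lower number from compound 1 to compound 4 (0.15 log units; within the scatter) and so leaves the number unchanged within the scatter on the sulfonyl series. With the chlorophenyl held constant, the sulfonyl chain of compound 4 can be compared directly with the carbonyl chain of compound 2, giving a 2.3-fold higher number from compound 2 to compound 4 (0.36 log units; beyond the scatter) as a modest change, while the comparison with the benzamide gives a 1.2-fold higher number from compound 3 to compound 4 (0.07 log units; within the scatter) and stays within the scatter. No measurement is available to explain these steps. Going by these compounds, it remains open whether an amine or a carboxylic acid in place of chloro on this ring would shift the number, and whether a longer chain would do so.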